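The compounds below may be only part of what the source reports. "The series", "measured", "known", "first", "only" and "open" are said of these compounds alone.

Compound 1 `CCCCC/C=C\C[C@]1(O)C=CC(=O)/C1=C/C=C\CCCC(=O)OC`: 7200 nM
Compound 2 `CCCCC/C=C\C[C@]1(O)C=CC(=O)/C1=C\C=C\CCCC(=O)OC`: 3900 nM
Compound 3 `CCCCC/C=C\C[C@@]1(O)C=C(I)C(=O)/C1=C/C=C/CCCC(=O)OC`: 3900 nM

In a functional assay on PC-3 cells (Homo sapiens) for cytotoxicity, read by sulforhodamine B assay, with a stated time of 72 h (a higher number here means a weaker inhibitor, a lower number a stronger inhibitor), compound 3 gives 3900 nM and stands level with compound 2 at these digits, with compound 1 within the scatter of both. Compound 4 `CCCCC/C=C\C[C@@]1(O)C=C(Br)C(=O)/C1=C/C=C/CCCC(=O)OC` carries bromo in place of iodo on a double-bonded ring carbon. Among the compounds with values here, the one measured step is a 1.8-fold lower number from compound 1 to compound 2 (0.27 log units; within the scatter), and it bears only indirectly on this change, given the fact that compounds 1 and 2 differ only in the configuration as drawn and the absence of any halogen exchange. With compound 3 at 3900 nM as the closest reference, the estimated step of a 1.3-fold lower number from compound 3 to compound 4 (0.11 log units; within the scatter) is expected to stay within the scatter. For compound 4 the estimate is 3000 nM, with an expected range from 1200 nM to 7500 nM.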

Compound 4, half-maximal inhibitory concentration: 5600 nM
Compound 4: middle estimate off by 1.9-fold (0.27 log units), on the low side; the measured number falls inside the stated range.
By their numbers in this assay, from the lowest: compounds 2, 3, 4 and 1 (each within the scatter of the next).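

In this assay, within the data shown here, the first halogen exchange at this double-bonded ring carbon, two ring bonds from the ring atom that bears a hydroxy group, gives a 1.4-fold higher number from compound 3 to compound 4 (0.16 log units; within the scatter). Iodo and bromo at this position therefore cannot be told apart by this read-out. The earlier compounds could not show this, because the only step among them involved no halogen exchange: the fact that compounds 1 and 2 differ only in the configuration as drawn

As far as these compounds go, what chloro, an amine or a plain hydrogen on this carbon would do remains open. Whether the halogen matters at all is therefore also unresolved.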